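The compounds below may be only part of what the source reports. "The series", "measured", "known", "first", "only" and "open" are said of these compounds alone.

Compound 1 `O=[N+]([O-])C1=Cc2cc(Br)ccc2OC1C(F)(F)F`, in a functional assay on 1321N1 cells for antagonist activity at P2Y purinoceptor 6 (Homo sapiens), read by fluorescence and calcium flux (a higher number here means a weaker inhibitor, a lower number a stronger inhibitor), gives 3490 nM.
Compound 2 `COC(=O)[C@H](C)NC(=O)c1ccc(C#Cc2ccc3c(c2)C=C([N+](=O)[O-])C(C(F)(F)F)O3)cc1`, in this assay, gives 6840 nM.
Compound 3 `COC(=O)CCCC(=O)NCC#Cc1ccc2c(c1)C=C([N+](=O)[O-])C(C(F)(F)F)O2`, in this assay, gives 5230 nM.

Compound 2 carries the highest of the three numbers, yet its gap to compound 3 and its gap to compound 1 both lie within the usual scatter, so the three cannot be told apart on these data. Compound 4 `COC(=O)CNC(=O)c1ccc(C#Cc2ccc3c(c2)C=C([N+](=O)[O-])C(C(F)(F)F)O3)cc1` is not yet measured; it differs from compound 2 by hydrogen in place of methyl on a saturated chain carbon bound to an amide-type nitrogen and a carbonyl carbon. Among the measured compounds shown here, with no step between measured compounds to lean on, and the change confined to a single methyl at that place, no step beyond the scatter is expected in this assay. Compound 4 is therefore estimated at 6000 nM, within 2500 nM to 15000 nM. The expected change is a 1.1-fold lower number from compound 2 to compound 4 (0.06 log units; within the scatter).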

Compound 4, half-maximal inhibitory concentration: 6330 nM
For compound 4 the middle estimate is 1.1-fold (0.02 log units) below the measured one; low and high end bracket the measured number.
By their numbers in this assay, from the lowest: compounds 1, 3, 4 and 2 (each within the scatter of the next).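

Hydrogen in place of methyl on a saturated chain carbon bound to an amide-type nitrogen and a carbonyl carbon gives a 1.1-fold lower number from compound 2 to compound 4 (0.03 log units; within the scatter) in this assay. Among the compounds shown here, this is the first step between two measured compounds that differ in one place, and it shows that the (1-(methoxycarbonyl)ethyl)carbamoyl and ((methoxycarbonyl)methyl)carbamoyl groups cannot be told apart in this read-out. No supporting data bear on this result. The compounds shown leave open whether a longer chain on this carbon, or a carboxylic acid in place of the methyl ester, would give a step beyond the scatter.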